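A Carboxylic Acid Chain in Place of a Cyclic Amine

The compounds below may be only part of what the source reports. "The series", "measured", "known", "first", "only" and "open" are said of these compounds alone.

The series rests on a shared core that appears twice in compound 1 `O=C(Nc1ccc2[nH]cc(C3CCN(CCCCCCN4CCC(c5c[nH]c6ccc(NC(=O)c7ccc(F)cc7)cc56)CC4)CC3)c2c1)c1ccc(F)cc1`, joined through a hexyl linker. In an assay on CHO-K1 cells for displacement of a labelled ligand from 5-hydroxytryptamine receptor 1D (Homo sapiens), read by scintillation counting (a lower number here means a stronger inhibitor, a higher number a weaker inhibitor), compound 1 gives 0.6 nM. Compound 2 `O=C(Nc1ccc2[nH]cc(C3CCN(CCN4CCCCC4)CC3)c2c1)c1ccc(F)cc1` carries that core once, ending in a cyclic amine on a short chain. In this assay compound 2 is recorded only as a limit, > 1000 nM, so no number is known for it. That is where compound 2 stands: the limit of > 1000 nM in this assay, at which 1 of the 2 values shown sits, and nothing sharper can be said about it.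

Compound 3 `O=C(O)CCCCCCCCCN1CCC(c2c[nH]c3ccc(NC(=O)c4ccc(F)cc4)cc23)CC1` has not yet been measured in this assay. It differs from compound 2 in one place: 7-carboxyheptyl in place of piperidin-1-yl on a saturated chain carbon, two bonds along the chain from an amine nitrogen in a ring. The group that enters is a long chain closed by a carboxylic acid, while a ring leaves. With only a limit on compound 2, the size of the step cannot be read from the data. The expected step from compound 2 to compound 3 is a step that the limit leaves unreadable from compound 2 to compound 3, a value expected to stay near the limit rather than move far in either direction. Compound 3 is therefore estimated at 3000 nM in this assay, with a range from 300 nM to 30000 nM, and a real chance that it too is reported only as a limit.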

Compound 3, inhibition constant: > 1000 nM
Compound 3 ended at the assay's limit; the forecaster's own chance of this, stated with the estimate: 60%; the middle value does not contradict the limit.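

In this assay compound 3 is recorded only as a limit (> 1000 nM). Compound 2 is also recorded only as a limit (> 1000 nM). For the compounds shown here, no step from compound 2 to compound 3 can therefore be read. The compounds shown leave open what the true values of compound 2 and compound 3 are, and whether 7-carboxyheptyl in place of piperidin-1-yl changes the value at all.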